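This account rests on a few compounds, and the source may have more. Where it says the series, first, only, none or still open, it means among the compounds named here.

Of the compounds shown here, three have been tested so far in a functional assay on HeLa cells (Homo sapiens) for antiproliferative activity, read by MTT assay, with a stated time of 48 h; on this read-out higher numbers stand for weaker inhibition and lower numbers for stronger inhibition. Compound 1 `COc1ccc2nc(Nc3ccnc(Nc4ccc(S(N)(=O)=O)cc4)n3)sc2c1` gives 1730 nM, the lowest of the three numbers. Compound 2 `CS(=O)(=O)c1ccc(Nc2ncc(F)c(Nc3nc4ccccc4s3)n2)cc1` gives 3170 nM, a number that lies within the scatter of compound 1, while compound 3 `NS(=O)(=O)c1ccc(Nc2ncc(F)c(Nc3nc4ccc(Cl)cc4s3)n2)cc1` gives 8770 nM, a gap from compound 1 that goes beyond the scatter. Compound 4 `Cc1ccc2nc(Nc3ccnc(Nc4ccc(S(N)(=O)=O)cc4)n3)sc2c1` has not yet been measured; it differs from compound 1 by methyl in place of methoxy on an aromatic carbon. Going by the values given here, no measured pair shows a step of this kind, so its size cannot be read from the data; such a small change is expected to stay within the scatter of this assay, with no clear direction. Compound 4 is therefore estimated at 2000 nM, with a range from 700 nM to 6000 nM, meaning an expected step of a 1.2-fold higher number from compound 1 to compound 4 (0.06 log units; within the scatter).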

Compound 4, half-maximal inhibitory concentration: 660 nM
Compound 4: middle estimate off by 3.0-fold (0.48 log units), on the high side; measured number below the stated range.
By their numbers in this assay, from the lowest: compound 4; then compounds 1 and 2 (each within the scatter of the next); then compound 3.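

Methyl in place of methoxy, on an aromatic carbon of the six-membered ring of carbon only, gives a 2.6-fold lower number from compound 1 to compound 4 (0.42 log units; beyond the scatter). Going by these compounds alone, this is the first pair differing in one place, and it shows that this position responds to a single-group change, with a modest step beyond the scatter. No evidence at hand accounts for the direction of this step. From the compounds shown here alone, how an ethyl group, a trifluoromethyl group or an amine would read at this position remains open, as does whether methyl would give a similar step on the other cores.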